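A few compounds are considered here, and "the series" means these few. Any claim that something is new, unique, unknown or untested is made for them only; others in the source may bear on it.

Of the compounds shown here, two built on the same core have been measured in a functional assay on OVCAR-3 cells (Homo sapiens) for inhibition, read by MTT assay, with a stated time of 24 h; a higher number here means a weaker inhibitor, a lower number a stronger inhibitor. Compound 1, `Cc1ccc(-n2cc(CN3C(=O)C[C@@H]4CC[C@@]3(C)C4(C)C)nn2)cc1`, gives 40 nM. Compound 2, `CC1(C)[C@H]2CC[C@]1(C)N(Cc1cn(-c3ccccc3C#N)nn1)C(=O)C2`, gives 110 nM, the higher of the two numbers. Within the data shown here, the only measured step is a 2.8-fold higher number from compound 1 to compound 2 (0.44 log units; beyond the scatter), which exchanges the whole group on the aromatic nitrogen. Compound 3, `CC1(C)[C@H]2CC[C@]1(C)N(Cc1cn(-c3ccccc3Br)nn1)C(=O)C2`, keeps the core and alters one group on that phenyl ring: bromo in place of cyano on an aromatic carbon. Among the measured compounds shown here, no measured pair swaps a bromo for a cyano, so the step between the first two compounds bears on this change only loosely, as a sign that the group on this ring can shift the number by a modest amount. For compound 3 the expected step is a 1.2-fold lower number from compound 2 to compound 3 (0.09 log units; within the scatter), at most a modest move in either direction. The estimate for compound 3 is 90 nM, with an expected range from 40 nM to 200 nM.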

Compound 3, half-maximal inhibitory concentration: 140 nM
Compound 3: the middle estimate sits 1.6-fold (0.19 log units) below what was measured; low and high end bracket the measured number.
By their numbers in this assay, from the lowest: compound 1; then compounds 2 and 3 (each within the scatter of the next).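

Exchanging cyano for bromo on this aromatic carbon, ortho to a large group, gives a 1.3-fold higher number from compound 2 to compound 3 (0.10 log units; within the scatter) in this assay and so leaves compound 2 and compound 3 indistinguishable, although the leaving group has two heavy atoms and a hydrogen-bond acceptor, while the entering group is a single bromine atom. The comparison with the 4-methylphenyl group shows a 3.5-fold higher number from compound 1 to compound 3 (0.54 log units; beyond the scatter) and so places the second 2-substituted ring beyond the scatter of compound 1, but this step alters both the group and its place on the ring, so it cannot separate those two changes. Nothing available here gives a measured reason for these numbers.

From the compounds shown here alone, it remains open whether an amine or a methoxy group at this same place would also leave the number unmoved. Also open, going by these compounds, is how a plain phenyl ring, without any added group, would compare with these compounds.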